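Replacing the pyridine amide with an open-chain amine

This account rests on a few compounds, and the source may have more. Where it says the series, first, only, none or still open, it means among the compounds named here.

compound 1 `O=C(Nc1cccc(Nc2ncc(F)c(Nc3ccc(F)cc3)n2)c1)c1cnccn1`: 23600 nM
compound 2 `O=C(Nc1cccc(Nc2ncc(F)c(Nc3ccc(F)cc3)n2)c1)c1ccncc1`: 5280 nM

Within the data shown here, in a functional assay on KB cells (Homo sapiens) for antiproliferative activity, read by sulforhodamine B assay, with a stated time of 3 days (a higher number here means a weaker inhibitor of growth, a lower number a stronger inhibitor of growth), compound 2 gives 5280 nM, the lower of the two numbers so far. Next is compound 3 `CN(C)CC(=O)Nc1cccc(Nc2ncc(F)c(Nc3ccc(F)cc3)n2)c1`, with (dimethylamino)methyl in place of pyridin-4-yl on a carbonyl carbon. Among the measured compounds shown here, only one measured step bears on this place, the modest one a 4.5-fold lower number from compound 1 to compound 2 (0.65 log units; beyond the scatter), and it lies beyond the scatter. That step exchanged one ring for another, whereas the incoming group has no ring, so it offers a guide to size only and none to direction. No clear shift is expected, though a change of similar size either way remains possible. The expected change is a 1.1-fold lower number from compound 2 to compound 3 (0.02 log units; within the scatter). For compound 3 the estimated value is 5000 nM, with an expected range of 1500 nM to 18000 nM.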

Compound 3, concentration for 50% growth inhibition: 1260 nM
The estimate for compound 3 lay 4.0-fold (0.60 log units) above the measured number, and the stated range ends above it.
By their numbers in this assay, from the lowest: compound 3; then compound 2; then compound 1.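

In this assay, an aromatic ring on this carbonyl carbon is not needed for growth inhibition: the open-chain (dimethylamino)methyl group gives a 4.2-fold lower number from compound 2 to compound 3 (0.62 log units; beyond the scatter) and a 19-fold lower number from compound 1 to compound 3 (1.27 log units; beyond the scatter). Among these compounds, earlier, this place had been seen only with aromatic rings, and the group with no ring and fewer heavy atoms now gives the lowest of the three numbers. Nothing available accounts for this gain.

The compounds shown do not separate the amine nitrogen from the loss of the ring, so the result for a plain alkyl chain without nitrogen at this place remains open. Also open, going by these compounds, is how a longer chain between the carbonyl and the dimethylamino group, or a morpholine in place of the dimethylamino group, would read in this assay.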